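Shortening the chain on the core of compound 3

The source may report more compounds than this note shows. Statements on the series, on what has been measured and on what is new or still open speak of the compounds shown alone.

In an ADME assay on HeLa cells (Homo sapiens) for cytotoxicity, read by sulforhodamine B assay, with a stated time of 48 h, tested at 10 uM (on this read-out lower numbers stand for less inhibition and higher numbers for more inhibition at the one concentration tested (going by the name of the read-out)), compound 1 `CCCCCCCc1cn(C(c2ccccc2)c2cc3cc(Br)ccc3nc2OC)nn1` gives 9.7%, compound 2 `COc1nc2ccc(Br)cc2cc1C(c1ccccc1)n1cc(-c2ccccc2F)nn1` gives 14.1%, and compound 3 `CCCCCc1cn(C(c2ccccc2)c2cc3cc(Br)ccc3nc2OC)nn1` gives -9.81%, the lowest of the three numbers, with its nearest neighbour compound 1 and its furthest compound 2; both of its steps to the other compounds are beyond the scatter. Compound 4 `CCCc1cn(C(c2ccccc2)c2cc3cc(Br)ccc3nc2OC)nn1` differs from compound 3 by hydrogen in place of ethyl on a saturated chain carbon, three bonds along the chain from an aromatic carbon. The step that bears most on this change is the one from heptyl to pentyl, where the number went down a number 19.5 percentage points lower from compound 1 to compound 3 (beyond the scatter); the step of a number 23.9 percentage points lower from compound 2 to compound 3 (beyond the scatter) also ended on compound 3. Since compound 3 already sits near no inhibition in this assay, a further shortening of the chain is expected to move the number only a little, and the author estimates a step of a number 2.2 percentage points lower from compound 3 to compound 4 (within the scatter), not beyond the scatter. Compound 4 is therefore expected to give about -12% in this assay, within a range from -30% to 8%.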

Compound 4, a percentage reported as inhibition, at one concentration (the size of the read-out at that concentration, not a potency): -2.25%
Compound 4: the middle estimate sits 9.8 percentage points below what was measured; measured number inside the range.
By their numbers in this assay, from the lowest: compounds 3 and 4 (each within the scatter of the next); then compounds 1 and 2 (each within the scatter of the next).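

In this assay, the change from pentyl to propyl gives a number 7.6 percentage points higher from compound 3 to compound 4 (within the scatter), so this shortening, unlike the earlier one from heptyl to pentyl, cannot be told from the scatter. Propyl still stands apart from the larger groups at the same place: heptyl to propyl gives a number 12 percentage points lower from compound 1 to compound 4 (beyond the scatter) and 2-fluorophenyl to propyl gives a number 16.4 percentage points lower from compound 2 to compound 4 (beyond the scatter), so compound 3 and compound 4 form a low pair, with compound 1 and compound 2 as a higher pair. No evidence at hand bears on what lies behind this split.

Going by these compounds, whether methyl or an amine in place of the propyl would stay with the low pair remains open. So does the reading for a chain longer than heptyl.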